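The source may hold more compounds than are shown below. What is called first, only, known or untested is meant among the compounds shown, and "the series" means these compounds.

The measured compounds:
compound 1, `CCCCCCCCS(=O)(=O)Nc1cc(-c2ccccc2Cl)ccc1C(=O)O`: 26900 nM
compound 2, `CCCCCCCCS(=O)(=O)Nc1cc(-c2cccc(F)c2)ccc1C(=O)O`: 32600 nM
compound 3, `CCCCCCCCS(=O)(=O)Nc1ccc(-c2ccccc2Cl)cc1C(=O)O`: 14400 nM

All three were tested in an assay on mitochondria (strain BALB/c) for inhibition of glycerol-3-phosphate acyltransferase 1, mitochondrial (Mus musculus), read by scintillation counting, with a stated time of 10 min; a higher number here means a weaker inhibitor, a lower number a stronger inhibitor. Compound 3 gives the lowest of the three numbers; compound 1 stands closest to it, within the scatter, while the gap from compound 3 to compound 2 lies just beyond it. Compound 1 and compound 2 differ only in the ring attached to the shared core, and that step, a 1.2-fold higher number from compound 1 to compound 2 (0.08 log units; within the scatter), stays within the scatter.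

Compound 4, `CCCCCCCCS(=O)(=O)Nc1ccc(-c2ccccc2OC)cc1C(=O)O`, differs from compound 3 in one place: methoxy in place of chloro on an aromatic carbon. Among the measured compounds shown here, no measured pair shows a chloro changed to a methoxy, so the only guidance is indirect. For the measured compounds named here, the one measured step that changes a substituent on that outer ring is the step from compound 1 to compound 2, and it produced no movement beyond the scatter. A change of similar scale is therefore expected here, with no clear direction. For compound 4 the expected step is a 1.3-fold higher number from compound 3 to compound 4 (0.10 log units; within the scatter), a shift within the scatter, because the comparable ring change a 1.2-fold higher number from compound 1 to compound 2 (0.08 log units; within the scatter) also stayed within it. Compound 4 is estimated at 18000 nM in this assay, with a range from 7000 nM to 45000 nM.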

Compound 4, half-maximal inhibitory concentration: 27600 nM
Beside the measured number, compound 4's estimate is 1.5-fold (0.19 log units) below it; measured number inside the range.
By their numbers in this assay, from the lowest: compounds 3, 1, 4 and 2 (each within the scatter of the next, the first and the last beyond it).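

In this assay, putting methoxy in place of chloro on an aromatic carbon ortho to a large group gives a 1.9-fold higher number from compound 3 to compound 4 (0.28 log units; within the scatter) and so stays within the scatter, which means this assay cannot tell compound 3 and compound 4 apart. Among the compounds shown here, this is the first comparison here in which the substituent's place stays fixed and only the group changes, whereas compound 1 and compound 2 differ in both the group and where it sits on the attached ring. One heavy atom gives way to two and a hydrogen-bond acceptor enters without a step beyond the scatter, and nothing available here explains this result.

The compounds shown leave open whether a group of a different kind at this same place, such as an amine or a carboxylic acid, would move the number beyond the scatter. They also leave open whether 2-methoxyphenyl would behave in the same way on the core of compound 1, where the attached ring sits elsewhere relative to the acid and the sulfonamide.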